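Chloro to propyl on the aromatic carbon: compound 4

The compounds below may be only part of what the source reports. "The series", "measured", "known", "first", "only" and "open" are said of these compounds alone.

Measured so far in an ADME assay (liver, Mus musculus) for metabolic stability, using microsomes, with a stated time of 10 min; a lower number here means that less of the compound is left, a higher number that more of the compound is left:
compound 1, `CCCS(=O)(=O)N1CC=C(c2ccc3c(c2)CC(C2CCN(Cc4ccccc4)CC2)O3)CC1`: "not determined" (no result reported)
compound 2, `CCCS(=O)(=O)N1CC=C(c2ccc3c(c2)CC(C2CCN(c4ncc(Cl)cn4)CC2)O3)CC1`: 45%
compound 3, `CCCS(=O)(=O)N1CC=C(c2ccc3c(c2)CC(C2CCN(c4ncc(C5CC5)cn4)CC2)O3)CC1`: 3%

Of the two numbers in hand, compound 2 stands highest in this assay. Its nearest neighbour is compound 3, which sits lower by a number 42 percentage points lower from compound 2 to compound 3 (beyond the scatter), a change that reads cyclopropyl in place of chloro on an aromatic carbon. Compound 1 carries no result and gives no bearing.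

Compound 4, `CCCc1cnc(N2CCC(C3Cc4cc(C5=CCN(S(=O)(=O)CCC)CC5)ccc4O3)CC2)nc1`, differs from compound 2 as follows: propyl in place of chloro on an aromatic carbon. For the measured compounds named here, the only measured step that bears on this is the one to compound 3, where a small carbon group took the place of the same chloro at the same position and the fall was large, beyond the scatter. A propyl entering at that spot is taken to behave in the same sense, so a downward step of similar size is expected, estimated at a number 37 percentage points lower from compound 2 to compound 4 (beyond the scatter). Compound 4 is therefore expected to give 8% in this assay, within a range of 1% to 25%.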

Compound 4, percent of the compound remaining: 58%
For compound 4 the middle estimate is 50 percentage points below the measured one; measured number outside the range, above it.
By their numbers in this assay, from the lowest: compound 3; then compound 2; then compound 4.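

At this aromatic carbon, carbon groups in place of chloro do not move this assay in one direction: the change from 5-chloropyrimidin-2-yl to 5-propylpyrimidin-2-yl goes upward (a number 13 percentage points higher from compound 2 to compound 4 (beyond the scatter)), against the downward cyclopropyl step (a number 42 percentage points lower from compound 2 to compound 3 (beyond the scatter)). Propyl and cyclopropyl at the same place stand far apart (a number 55 percentage points higher from compound 3 to compound 4 (beyond the scatter)), so the loss of chloro alone does not set the outcome; the group that enters matters. Nothing at hand accounts for the gap between these two groups.

Open, as far as these compounds go, is whether the number holds for a shorter ethyl, a branched isopropyl or a longer butyl chain at this carbon. Also open, from the compounds shown here alone, is how an amine or a methoxy group at the same carbon would compare with propyl and chloro on the shared core.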